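Chloro to phenyl on the aryl ring: an estimate

The compounds below may be only part of what the source reports. "The series", "measured", "known", "first", "only" and "open" are said of these compounds alone.

Three compounds of the series carry a number in an assay for binding affinity to adenosine receptor A1 (Bos taurus); on this read-out higher numbers stand for weaker inhibition and lower numbers for stronger inhibition. Compound 1 `Cn1c(=O)c2nc(-c3cccc(F)c3)[nH]c2n(C)c1=O` gives 4 nM. Compound 2 `CCn1c(=O)c2nc(-c3ccc(S(=O)(=O)N4CCOCC4)cc3)[nH]c2n(CC)c1=O`, which carries ethyl groups on the shared core and a sulfonyl-morpholine on its aryl ring, gives 13 nM. Compound 3 `Cn1c(=O)c2nc(-c3ccc(Cl)cc3)[nH]c2n(C)c1=O` gives 0.8 nM, the lowest of the three numbers; its gap to compound 1 and its larger gap to compound 2 both lie beyond the usual scatter, so compound 3 is the most potent of the measured set in this assay.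

Compound 4 `Cn1c(=O)c2nc(-c3ccc(-c4ccccc4)cc3)[nH]c2n(C)c1=O` has not yet been measured. It differs from compound 3 by phenyl in place of chloro on an aromatic carbon. No step between two measured compounds isolates this change, so the expectation rests on the spread of the numbers already shown. Within the data shown here, compound 2 is the only measured compound with a large group on the aryl ring, and it gives the weakest number of the three, though it also differs from compound 3 in the groups on the shared core. A move toward weaker binding is therefore expected, of moderate size, with the step from compound 3 to compound 4 estimated at a 19-fold higher number from compound 3 to compound 4 (1.27 log units; beyond the scatter). For compound 4 the expected value in this assay is 15 nM, within a range of 4 nM to 60 nM.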

Compound 4, half-maximal inhibitory concentration: 3.5 nM
Compound 4: middle estimate off by 4.3-fold (0.63 log units), on the high side; the measured number lies below the stated range.
By their numbers in this assay, from the lowest: compound 3; then compounds 4 and 1 (each within the scatter of the next); then compound 2.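

Phenyl in place of chloro on an aromatic carbon, para to a large group, is the first change in the series that can be read in one place, and in this assay it gives a 4.4-fold higher number from compound 3 to compound 4 (0.64 log units; beyond the scatter) on the aryl ring. The position therefore accepts a six-membered aromatic ring of carbon only in place of a single chlorine at a modest cost, with compound 4 still at 3.5 nM in this read-out, so a large group at this place does not by itself bring a large loss here. No measurement at hand explains the size of this step.

Going by these compounds, whether an amine, a carboxylic acid or a methoxy group at this position would give a number closer to that of compound 3 or that of compound 4 stays open, as does whether a saturated cyclohexyl ring would behave as phenyl does. Also open, on these data alone, is whether the same change gives a step of similar size with ethyl groups on the shared core, as carried by compound 2.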